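A few compounds are considered here, and "the series" means these few. Any claim that something is new, unique, unknown or untested is made for them only; others in the source may bear on it.

Measured in a physicochemical assay for lipophilicity, read by HPLC, at pH 7.5; a lower number here means a more polar compound, a higher number a more lipophilic compound:
- Compound 1 `CC[C@@H](Nc1c(C#N)c(-c2ccc(-c3cccc(Cl)c3F)cc2)nc2cnccc12)C(N)=O`: 3.1
- Compound 2 `CC[C@@H](Nc1c(C#N)c(-c2ccc(-c3ccccc3NC)cc2)nc2cnccc12)C(N)=O`: 2.5

Of these two compounds, compound 2 stands lowest at 2.5. Compound 1 reads 3.1, and the gap between the two lies beyond the scatter. The next compound to be read is compound 3 `CC[C@@H](Nc1c(C#N)c(-c2ccc(-c3ccccc3Cl)cc2)nc2cnccc12)C(N)=O`, which is still unmeasured. It departs from compound 2 by one change, chloro in place of methylamino on an aromatic carbon, ortho to a large group. The same difference can be read as 2-(methylamino)phenyl to 2-chlorophenyl.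

Within the data shown here, only one measured step bears on this change, a number 0.60 log units lower from compound 1 to compound 2 (beyond the scatter). There, 2-(methylamino)phenyl took the place of 3-chloro-2-fluorophenyl, and the step was modest. The change to compound 3 also removes 2-(methylamino)phenyl, but it puts a different halogenated phenyl in its place, so the evidence is indirect. A rise in this assay of modest size is therefore expected, close to the reverse of that single step. The expected size is a number 0.50 log units higher from compound 2 to compound 3 (beyond the scatter). For compound 3 the estimated value is 3, with an expected range of 2.6 to 3.4.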

Compound 3, distribution coefficient: 2.9
Beside the measured number, compound 3's estimate is 0.10 log units above it; low and high end bracket the measured number.
By their numbers in this assay, from the lowest: compound 2; then compounds 3 and 1 (each within the scatter of the next).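

In this assay, putting chloro in place of methylamino on the aromatic carbon, ortho to a large group, gives a number 0.40 log units higher from compound 2 to compound 3 (beyond the scatter). Among these compounds, this is the first step here in which only that one group changes, with the rest of the phenyl left as it stands in compound 2. The other new comparison, 2-chlorophenyl in place of 3-chloro-2-fluorophenyl, gives a number 0.20 log units lower from compound 1 to compound 3 (within the scatter), so this assay does not separate these two halogenated phenyl groups, and among the three compounds only compound 2, which carries the methylamino group, stands apart; the data shown offer no measurement that would account for this difference.

The compounds shown leave open whether compound 2 would stay apart from groups such as a plain amine, a dimethylamino group, a methoxy group or a carboxylic acid on the same aromatic carbon. They also leave open whether a lone fluoro at that carbon would read with the chloro of compound 3 or with the methylamino of compound 2.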